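Replacing (3-chloropropyl)amino with vinyl in compound 2

The source may report more compounds than this note shows. Statements on the series, on what has been measured and on what is new or still open speak of the compounds shown alone.

Among the compounds with values here, in a functional assay on MCF7 cells (Homo sapiens) for antiproliferative activity, with a stated time of 48 h (a lower number here means a stronger inhibitor, a higher number a weaker inhibitor), compound 2 `CC(C)(C)c1ccc(NC(=O)NCCCCl)cc1` gives 49000 nM, the only true number so far. Compound 1 `O=C(NCCCCl)Nc1ccc(I)cc1` stops at a limit of the assay, > 100000 nM. Compound 3 `O=C(CCCCl)Nc1ccc(I)cc1` also stops at a limit, > 100000 nM. Compound 4 `C=CC(=O)Nc1ccc(C(C)(C)C)cc1` differs from compound 2 by one change: vinyl in place of (3-chloropropyl)amino on a carbonyl carbon. Within the data shown here, two measured steps bear on this change. The first, an at least 2.0-fold lower number from compound 1 to compound 2 (0.30 log units; that floor lies within the scatter), alters a different group. The second, a step that the two limits leave unreadable from compound 1 to compound 3, also alters a group on a carbonyl carbon, but its size cannot be read. No step beyond the scatter is therefore expected in this assay, and the estimated step is a 1.0-fold higher number from compound 2 to compound 4 (0.01 log units; within the scatter). For compound 4 the expected value is 50000 nM, with an estimated range of 20000 nM to 100000 nM.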

Compound 4, half-maximal inhibitory concentration: 29000 nM
The estimate for compound 4 lay 1.7-fold (0.24 log units) above the measured number, within the range that was stated.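

In this assay, within the data shown here, the step of a 1.7-fold lower number from compound 2 to compound 4 (0.23 log units; within the scatter) is the first readable one for a change on this carbonyl carbon. With tert-butyl kept in place, the chlorine-bearing (3-chloropropyl)amino group and its hydrogen-bond donor can give way to vinyl with no change beyond the scatter. Any role for the chlorine in this activity therefore finds no support in this pair.

Going by these compounds, whether a longer chain or a cyclic amine at this place would behave the same remains open. The steps among the iodo compounds cannot be read, so this pair stands alone: the limit of > 100000 nM in this assay, at which 2 of the 4 values shown sit.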